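The compounds below may be only part of what the source reports. "The series", "measured", "known", "first", "only" and "open" are said of these compounds alone.

Three compounds share one core and differ only in the group on a six-membered aromatic ring of carbon only. Compound 1 `Cc1c(C(=O)NCCCN2CCN(C)CC2)c(-c2cccc(N3CCN(c4ccc(NS(=O)(=O)c5cccc(S(=O)(=O)C6CC6)c5)cc4)CC3)c2)c(-c2ccc(Cl)cc2)n1C` carries a cyclopropylsulfonyl group there and in an assay for binding affinity to Apoptosis regulator Bcl-2 (Homo sapiens), read by fluorescence polarization, with a stated time of 2 h (a lower number here means a stronger inhibitor, a higher number a weaker inhibitor), compound 1 gives 218 nM. Compound 2 `Cc1c(C(=O)NCCCN2CCN(C)CC2)c(-c2cccc(N3CCN(c4ccc(NS(=O)(=O)c5cccc(OC(C)C)c5)cc4)CC3)c2)c(-c2ccc(Cl)cc2)n1C` carries isopropoxy, and in this assay compound 2 gives 522 nM. Compound 3 `CCOc1cccc(S(=O)(=O)Nc2ccc(N3CCN(c4cccc(-c5c(C(=O)NCCCN6CCN(C)CC6)c(C)n(C)c5-c5ccc(Cl)cc5)c4)CC3)cc2)c1` carries ethoxy, and in this assay compound 3 gives 420 nM. On the numbers as they stand, compound 3 sits second highest of the three, but both its gaps are within the scatter: a 1.9-fold higher number from compound 1 to compound 3 (0.28 log units; within the scatter) and a 1.2-fold lower number from compound 2 to compound 3 (0.09 log units; within the scatter). Only a 2.4-fold higher number from compound 1 to compound 2 (0.38 log units; beyond the scatter) reaches beyond it.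

Compound 4 `Cc1cccc(S(=O)(=O)Nc2ccc(N3CCN(c4cccc(-c5c(C(=O)NCCCN6CCN(C)CC6)c(C)n(C)c5-c5ccc(Cl)cc5)c4)CC3)cc2)c1` is made from compound 3 by methyl in place of ethoxy on an aromatic carbon. Among the compounds with values here, no measured step removes the oxygen at this position, so the measured steps bear on it only indirectly: exchanges at this position have moved this assay by a 1.9-fold higher number from compound 1 to compound 3 (0.28 log units; within the scatter) and by a 1.2-fold lower number from compound 2 to compound 3 (0.09 log units; within the scatter). A step of similar, modest size is therefore expected, a 1.2-fold higher number from compound 3 to compound 4 (0.08 log units; within the scatter), with no confident direction beyond the scatter. Compound 4 is estimated at 500 nM, between 200 nM and 1300 nM.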

Compound 4, inhibition constant: 178 nM
Beside the measured number, compound 4's estimate is 2.8-fold (0.45 log units) above it; the whole stated range lies above it.
By their numbers in this assay, from the lowest: compounds 4, 1, 3 and 2 (each within the scatter of the next, the first and the last beyond it).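

In this assay, putting methyl on this aromatic carbon gives a 2.4-fold lower number from compound 3 to compound 4 (0.37 log units; beyond the scatter) when ethoxy leaves and a 2.9-fold lower number from compound 2 to compound 4 (0.47 log units; beyond the scatter) when isopropoxy leaves, so this position responds clearly once the oxygen-linked group is gone, although ethoxy and isopropoxy themselves could not be told apart. The step to the sulfonyl compound, a 1.2-fold lower number from compound 1 to compound 4 (0.09 log units; within the scatter) and thus inside the scatter, means that methyl and cyclopropylsulfonyl cannot be separated at this position. Nothing given here explains why these exchanges move the number.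

A methoxy group at this position would help show whether the oxygen or the chain attached to it accounts for the step from ethoxy to methyl. From the compounds shown here alone, how an amine, a carboxylic acid or a longer carbon chain would fare at this position remains open.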